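Swapping the acid ring's methyl for chlorine

A few compounds are considered here, and "the series" means these few. Any claim that something is new, unique, unknown or untested is made for them only; others in the source may bear on it.

Within the data shown here, compound 1 `Cc1cc(C(=O)O)ccc1OCCCCOc1ccc(C(=O)CC(C)C)c(O)c1C` is the only member of this small set with a plain number: in an assay on HEK293 cells for positive allosteric modulation of metabotropic glutamate receptor 3 (Rattus norvegicus), read by thallium flux, with a stated time of 2.5 min (on this read-out lower numbers stand for an effect already at smaller amounts and higher numbers for an effect only at larger amounts of compound), compound 1 gives 1850 nM. Compound 2 `CCCC(=O)c1ccc(OCCCCOc2ccc(C(=O)O)cc2C)c(C)c1O` differs from it by one change, hydrogen in place of methyl on a saturated chain carbon bound to two saturated chain carbons, and that change brought an at least 5.4-fold higher number from compound 1 to compound 2 (0.73 log units; beyond the scatter). For compound 2 the result in this assay is a limit of the assay and not a number, > 10000 nM; this is the limit of > 10000 nM in this assay, at which 1 of the 3 values shown sits. Compound 3 `Cc1cc(C(=O)O)ccc1OCCCCOc1ccc(C(=O)C(C)C)c(O)c1C` has no result in this assay, where compound 3 is recorded as "not determined" (no result reported).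

Compound 4 `Cc1c(OCCCCOc2ccc(C(=O)O)c(Cl)c2)ccc(C(=O)CC(C)C)c1O` has not yet been measured. Its change from compound 1 is 4-carboxy-3-chlorophenyl in place of 4-carboxy-2-methylphenyl on an oxygen on a saturated carbon. Among the measured compounds shown here, the one measured step, from compound 1 to compound 2, concerns the ketone side chain and leaves the acid-bearing ring untouched, so it says nothing direct about a change on that ring. For the measured compounds named here, with no measured step touching this part of the molecule, no movement beyond the usual scatter is expected, and the expected step is a 1.4-fold higher number from compound 1 to compound 4 (0.13 log units; within the scatter). Compound 4 is therefore expected to give about 2500 nM in this assay, within a range from 800 nM to 8000 nM.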

Compound 4, half-maximal effective concentration: 2050 nM
Compound 4: the middle estimate sits 1.2-fold (0.09 log units) above what was measured; the range from low to high includes it.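

In this assay, 4-carboxy-3-chlorophenyl in place of 4-carboxy-2-methylphenyl gave a 1.1-fold higher number from compound 1 to compound 4 (0.04 log units; within the scatter), so compound 1 and compound 4 cannot be told apart on this read-out. Among these compounds, this is the first measured look at the acid-bearing ring, since the earlier step between measured compounds concerned only the ketone side chain at the other end of the molecule. It shows that, with the rest of compound 1 kept, this acid-bearing group on an oxygen on a saturated carbon can be exchanged for one carrying chlorine instead of methyl with no change beyond the scatter, a result that holds for this single pair only.

The name of the group also shows that the substituent's number changes from 2 to 3 along with the swap from methyl to chlorine, so the compounds shown cannot separate the two, and they leave open how 4-carboxy-2-chlorophenyl, 4-carboxy-3-methylphenyl or a ring bearing a methoxy group or a fluorine would read. Nothing measured among these compounds says why this exchange leaves the number within the scatter.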